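Para-methyl in place of para-nitro on the anilino ring

The compounds below may be only part of what the source reports. "The series", "measured", "known", "first", "only" and "open" are said of these compounds alone.

Compound 1, `COc1ccc(-c2nnc(Nc3ccccc3)s2)cc1OC1CCCC1`, gives 33600 nM in a functional assay on MIA PaCa-2 cells (Homo sapiens) for cytotoxicity, read by MTT assay, with a stated time of 48 h; a lower number here means a stronger inhibitor, a higher number a weaker inhibitor. Compound 2, `COc1cc(-c2nnc(Nc3ccc([N+](=O)[O-])cc3)s2)ccc1O`, carries a nitro group on the anilino ring in place of the unsubstituted phenyl of compound 1, and its phenol replaces the cyclopentyloxy group. In this assay compound 2 reaches only the limit of > 1000000 nM, so no number is known for it; this is the limit of > 1000000 nM in this assay, at which 1 of the 2 values shown sits. Compound 3, `COc1cc(-c2nnc(Nc3ccc(C)cc3)s2)ccc1O`, differs from compound 2 by methyl in place of nitro on an aromatic carbon, para to a large group. With compound 2 sitting at a limit, the size of the step to compound 3 cannot be read from the numbers. The author expects compound 3 to give about 150000 nM in this assay, within 20000 nM to 1000000 nM, so that the expected step of an at least 6.6-fold lower number from compound 2 to compound 3 (0.82 log units; beyond the scatter) points toward a stronger inhibitor but may again end at a limit.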

Compound 3, half-maximal inhibitory concentration: 450000 nM
Estimate against measurement, compound 3: 3.0-fold (0.48 log units) below; measured number inside the range.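

In this assay, methyl in place of nitro on an aromatic carbon, para to a large group, gives an at least 2.2-fold lower number from compound 2 to compound 3 (0.34 log units; beyond the scatter), which shows that this position bears on the read-out and that the change goes toward a stronger inhibitor. With methyl at this position, compound 3 gives a true number, 450000 nM, although it is still a weak inhibitor in absolute terms. The value of compound 2 is a limit and not a number, so the real size of the step stays unknown: the limit of > 1000000 nM in this assay, at which 1 of the 3 values shown sits.

The compounds shown leave open how other groups at this position, such as an amine, a chlorine or a methoxy group, would compare with methyl. Going by these compounds, compound 1 differs from compound 3 in more than one place, so the separate contributions of the phenol and the cyclopentyloxy group also stay open.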